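This account rests on a few compounds, and the source may have more. Where it says the series, first, only, none or still open, it means among the compounds named here.

Measured so far:
compound 1 `C/C(=C\CC/C(C)=C/CC[C@@H]1[C@@]2(C)CCC(=O)C(C)(C)[C@H]2CC[C@@]1(C)O)CC/C=C(\C)C(=O)OCc1cn(-c2ccccc2Cl)nn1` — > 150000 nM
compound 2 `C/C(=C\CC/C(C)=C/CC[C@@H]1[C@@]2(C)CCC(=O)C(C)(C)[C@H]2CC[C@@]1(C)O)CC/C=C(\C)C(=O)OCc1cn(-c2ccccc2)nn1` — 95500 nM

In a functional assay on DU-145 cells (Homo sapiens) for antiproliferative activity, read by MTT assay, with a stated time of 48 h (a higher number here means a weaker inhibitor, a lower number a stronger inhibitor), compound 1 reaches only a limit of the assay, > 150000 nM. Compound 2 gives 95500 nM. Among the compounds with values here, the single measured step, an at least 1.5-fold lower number from compound 1 to compound 2 (0.19 log units; that floor lies within the scatter), rests on the limit of > 150000 nM in this assay, at which 1 of the 2 values shown sits, and therefore says little about its true size. Compound 3 `C/C(=C\CC/C(C)=C/CC[C@@H]1[C@@]2(C)CCC(=O)C(C)(C)[C@H]2CC[C@@]1(C)O)CC/C=C(\C)C(=O)OCc1cn(-c2ccc(Br)cc2)nn1` differs from compound 1 by 4-bromophenyl in place of 2-chlorophenyl on an aromatic nitrogen. Within the data shown here, no measured step exchanges one halogen-bearing phenyl for another, so compound 1 is taken as the anchor. Compound 3 is expected to stay near the limit, a step of a number no higher from compound 1 to compound 3 (the limit leaves the size open). The estimate for compound 3 is 150000 nM, with a range from 70000 nM to 320000 nM.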

Compound 3, half-maximal inhibitory concentration: > 150000 nM
Compound 3: no number, only a limit; the forecaster's own chance of this, stated with the estimate: 55%; the middle value sits exactly at the limit.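

In this assay compound 3 gives only a limit, > 150000 nM. Bromo in place of hydrogen on the phenyl gives an at least 1.5-fold higher number from compound 2 to compound 3 (0.19 log units; that floor lies within the scatter), so a second halogen-bearing phenyl, after the 2-chlorophenyl, also shows no lower number, though the floor of that step does not clear the scatter. The step from 2-chlorophenyl to 4-bromophenyl cannot be read: the limit of > 150000 nM in this assay, at which 2 of the 3 values shown sit.

Where the true values of compound 1 and compound 3 lie remains open. So does whether an amine or a carboxylic acid on this phenyl would give a lower number.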